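Butoxycarbonyl to 1,3-oxazol-2-yl: working notes on compound 4

The source may hold more compounds than are shown below. What is called first, only, known or untested is meant among the compounds shown, and "the series" means these compounds.

Measured in a functional assay (aorta) with Rattus norvegicus as the target; on this read-out higher numbers stand for weaker inhibition and lower numbers for stronger inhibition:
- compound 1 `CCCCOC(=O)CN(c1ccccc1)[C@H]1c2cc(C#N)ccc2OC(C)(C)[C@@H]1O`: 27000 nM
- compound 2 `CCOC(=O)CN(c1ccc(F)cc1)[C@H]1c2cc(C#N)ccc2OC(C)(C)[C@@H]1O`: > 30000 nM (a limit, not a number)
- compound 3 `CCOC(=O)CN(c1ccc(Cl)cc1)[C@H]1c2cc(C#N)ccc2OC(C)(C)[C@@H]1O`: > 30000 nM (a limit, not a number)

In this assay, among the measured compounds shown here, compound 1 gives 27000 nM, the only true number in the set. The other two entries are not numbers: they stand at the limit of > 30000 nM in this assay, at which 2 of the 3 values shown sit.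

Compound 4 `CC1(C)Oc2ccc(C#N)cc2[C@H](N(Cc2ncco2)c2ccccc2)[C@H]1O` departs from compound 1 in one place: 1,3-oxazol-2-yl in place of butoxycarbonyl on a saturated chain carbon bound to a nitrogen on an aromatic ring. For the measured compounds named here, no measured step covers this change. Going by the values given here, the only step available, a step that the two limits leave unreadable from compound 2 to compound 3, concerns chloro in place of fluoro on an aromatic carbon, and it offers no size to carry over. The expectation therefore stays anchored on compound 1 at 27000 nM, and no shift beyond the scatter is expected in this assay. The estimated step is a 1.1-fold lower number from compound 1 to compound 4 (0.03 log units; within the scatter). For compound 4 the expected value is 25000 nM, with an estimated range of 9000 nM to 70000 nM.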

Compound 4, half-maximal inhibitory concentration: > 30000 nM
Compound 4: only a limit was reported (the forecaster's own chance of this, stated with the estimate: 60%); middle value at least 1.2-fold (0.07 log units) from the limit.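

In this assay the entry for compound 4 is a limit and not a number, and it joins most of the series: the limit of > 30000 nM in this assay, at which 3 of the 4 values shown sit. On the saturated chain carbon bound to a nitrogen on an aromatic ring, 1,3-oxazol-2-yl in place of butoxycarbonyl gives an at least 1.1-fold higher number from compound 1 to compound 4 (0.04 log units; that floor lies within the scatter), so no gain or loss can be claimed for this change. The earlier compounds shown here carried only esters at this place, and compound 4 adds that a five-membered aromatic ring there also gives no true number.

Steps between two limits cannot be read, and how far compound 4 lies past its limit stays open. Also open, from the compounds shown here alone, is whether a carboxylic acid or an amine at this place would give a true number in this assay.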